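A few compounds are considered here, and "the series" means these few. Any claim that something is new, unique, unknown or untested is made for them only; others in the source may bear on it.

Measured so far:
- compound 1 `CN(Cc1cccc(F)c1)C(=O)CCCNC(=O)c1ccc(S(C)(=O)=O)c([N+](=O)[O-])c1`: > 27000 nM
- compound 2 `CN(Cc1cccc(F)c1)C(=O)CN(C)C(=O)c1ccc(S(C)(=O)=O)c([N+](=O)[O-])c1`: > 27000 nM
- compound 3 `CC1CCN(C(=O)CCCNC(=O)c2ccc(S(C)(=O)=O)c([N+](=O)[O-])c2)CC1`: > 27000 nM

Working notes. In an ADME assay on HepG2 cells (Homo sapiens) for cytotoxicity, read by CellTiter-Glo and ATP content, with a stated time of 72 h (a higher number here means that more compound is needed for the effect, a lower number that less compound is needed), compound 1 gives > 27000 nM, which is a limit of the assay and not a number. In this assay compound 2 gives > 27000 nM, likewise a limit. In this assay compound 3 gives > 27000 nM, again a limit. The change from compound 1 to compound 3, (4-methylpiperidin-1-yl in place of (3-fluorobenzyl)(methyl)amino on a carbonyl carbon), gives a step that the two limits leave unreadable from compound 1 to compound 3; the two limits leave its size unreadable. All three values sit at the limit of > 27000 nM in this assay, at which 3 of the 3 values shown sit. The core of compound 1 and the core of compound 2 differ, but that difference is not broken down here.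

Compound 4 `CC1CCN(C(=O)CN(C)C(=O)c2ccc(S(C)(=O)=O)c([N+](=O)[O-])c2)CC1` is not yet measured in this assay. It differs from compound 2 by 4-methylpiperidin-1-yl in place of (3-fluorobenzyl)(methyl)amino on a carbonyl carbon; the surroundings of the place are described in the same words as for the step from compound 1 to compound 3, so it is the same change. The expected step in this assay is a step that the limit leaves unreadable from compound 2 to compound 4, resting on the measured step that the two limits leave unreadable from compound 1 to compound 3, which stayed at the limit. Compound 4 is therefore expected at about 40000 nM, between 20000 nM and 120000 nM, most likely reported as a limit.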

Compound 4, half-maximal effective concentration: > 27000 nM
Compound 4 was reported as a limit; the forecaster's own chance of this, stated with the estimate: 90%; the middle value does not contradict the limit.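

In this assay compound 4 gives > 27000 nM as a limit of the assay and not a number. Compound 2 gives > 27000 nM as a limit too, so no step can be read between compound 2 and compound 4. The compounds shown leave open what size, if any, the change to 4-methylpiperidin-1-yl has on this read-out, as every value sits at one limit: the limit of > 27000 nM in this assay, at which 4 of the 4 values shown sit.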